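This account rests on a few compounds, and the source may have more. Where it says the series, first, only, none or still open, it means among the compounds named here.

Values so far in a functional assay on HepG2 cells (Homo sapiens) for inhibition, read by MTT assay, with a stated time of 48 h; a lower number here means a stronger inhibitor, a higher number a weaker inhibitor:
- compound 1 (`c1ccc(-c2nn(-c3ccccc3)c3nccc(-c4cccs4)c23)cc1`) at 39300 nM
- compound 2 (`O=C(C=CNc1cc(-c2ccccc2)nn1-c1ccccc1)c1ccc(Br)cc1`) at 8810 nM
- compound 3 (`COc1ccc(-c2nc3c(c(-c4ccccc4)nn3-c3ccccc3)c(-c3ccc(N4CCN(C)CC4)cc3)c2C#N)cc1`) at 1330 nM

Compound 2 stands in the middle of these three numbers. Compound 1 has the higher number and compound 3 the lower, and both gaps to compound 2 lie beyond the scatter. Neither of these two differs from compound 2 in a single place, so their values give no measure of a one-place step in this assay and only frame the range seen so far.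

The next compound is compound 4 (`O=C(C=CNc1cc(-c2ccccc2)nn1-c1ccccc1)c1ccc(F)cc1`), which carries fluoro in place of bromo on an aromatic carbon, para to a large group (fluoro in place of bromo on an aromatic carbon). Within the data shown here, the rest of the structure is unchanged, so the estimate is anchored on compound 2 at 8810 nM and no measured step is available to size the change. No step beyond the scatter is expected, with a slight lean towards a higher number, meaning a somewhat weaker inhibitor. The expected change is a 1.4-fold higher number from compound 2 to compound 4 (0.13 log units; within the scatter) and remains uncertain. For compound 4 the estimated value is 12000 nM with an expected range of 4500 nM to 30000 nM as its bounds.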

Compound 4, half-maximal inhibitory concentration: 59900 nM
Estimate against measurement, compound 4: 5.0-fold (0.70 log units) below; the measured number lies above the stated range.
By their numbers in this assay, from the lowest: compound 3; then compound 2; then compounds 1 and 4 (each within the scatter of the next).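

In this assay the exchange of bromo for fluoro on an aromatic carbon, para to a large group, gives a 6.8-fold higher number from compound 2 to compound 4 (0.83 log units; beyond the scatter) and provides the first size for a one-place change in this series. The step shows that activity in this assay can respond to the identity of the halogen at this position, even though one heavy atom replaces one heavy atom and the counts of rings, hydrogen-bond donors, hydrogen-bond acceptors and net charge stay the same. No measurement shown here bears on the reason for this step.

Going by these compounds, this reading rests on a single pair, so it remains open whether the number follows a trend across the halogens, which chloro or iodo at the same place would test, or whether a methoxy group or an amine there would hold the value of compound 2 or that of compound 4. On these data alone, it also remains open whether the same exchange gives a step of similar size on the 4-bromophenyl carbonyl scaffold when the rest of the structure is changed.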